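The source may hold more compounds than are shown below. What is called first, only, known or untested is meant among the compounds shown, and "the series" means these compounds.

Measured so far in a functional assay on HEK293 cells (Homo sapiens) for cytotoxicity; on this read-out lower numbers stand for higher toxicity in this test and higher numbers for lower toxicity in this test:
Compound 1 `COc1ccc([C@H]2CC(=O)N(c3cc(N)cc(N)c3)C2)cc1OC1CCCC1` gives > 10000 nM as a limit.
Compound 2 `COc1ccc([C@H]2CC(=O)N(c3cccc(N)c3C)C2)cc1OC1CCCC1` gives > 10000 nM as a limit.
Compound 3 `COc1ccc([C@H]2CC(=O)N(c3ccccc3C(F)(F)F)C2)cc1OC1CCCC1` gives > 10000 nM as a limit.

Compound 3 therefore has no number of its own and stands at the limit of > 10000 nM in this assay, at which 3 of the 3 values shown sit, with no rank among the three. Compound 4 `COc1ccc([C@H]2CC(=O)N(c3cccc([S+](C)[O-])c3)C2)cc1OC1CCCC1` differs from compound 3 in one place, on an amide-type nitrogen in a ring (a group of 9 heavy atoms (7 carbon, 1 oxygen, 1 sulfur; one six-membered aromatic ring of carbon only) in place of a group of 10 heavy atoms (7 carbon, 3 fluorine; one six-membered aromatic ring of carbon only), on an amide-type nitrogen in a ring). Within the data shown here, the steps that bear on this change are those at the same place (a step that the two limits leave unreadable from compound 1 to compound 2; a step that the two limits leave unreadable from compound 1 to compound 3; a step that the two limits leave unreadable from compound 2 to compound 3), and none has a readable size. The expectation therefore rests on the limit of compound 3 (> 10000 nM) and on the same limit for compounds 1 and 2. No step beyond the scatter is expected in this assay, and no direction can be given. The expected change is a step that the limit leaves unreadable from compound 3 to compound 4 and most likely will show only as a limit again. Compound 4 is estimated at 20000 nM with an expected range from 8000 nM to 50000 nM and will most likely be reported as a limit.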

Compound 4, half-maximal cytotoxic concentration: > 10000 nM
Compound 4: only a limit was reported; the forecaster's own chance of this, stated with the estimate: 85%; the middle value is on the limit's open side.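

In this assay compound 4 gives > 10000 nM as a limit, so its steps from compound 1, compound 2 and compound 3 cannot be read. The compounds shown leave open how these groups on the amide-type nitrogen rank, and all that stands is this: the limit of > 10000 nM in this assay, at which 4 of the 4 values shown sit.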